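The compounds below may be only part of what the source reports. "The series", "measured", "known", "first", "only" and "open" are said of these compounds alone.

Compound 1, `C=CCn1ncc2c(C)nc(CC)n2c1=O`: > 48000 nM
Compound 2, `C=CCn1ncc2c(C)nc(CCC)n2c1=O`: 40000 nM
Compound 3, `CCc1nc(C)c2cnnc(O)n12`: > 48000 nM

All three were tested in a functional assay for inhibition, with Homo sapiens as the target; on this read-out higher numbers stand for weaker inhibition and lower numbers for stronger inhibition. Compound 2 gives 40000 nM. For compound 1 the assay reports only a limit, > 48000 nM. The step of an at least 1.2-fold higher number from compound 2 to compound 1 (0.07 log units; that floor lies within the scatter) goes with the change (hydrogen in place of methyl on a saturated chain carbon, two bonds along the chain from an aromatic carbon). For compound 3 the assay likewise reports only a limit, > 48000 nM. How the core of compound 3 differs from the core of compound 2 is not broken down here.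

Compound 4, `Cc1nc(C)n2c(O)nncc12`, is not yet measured. It differs from compound 3 by hydrogen in place of methyl on a saturated chain carbon bound to an aromatic carbon. For the measured compounds named here, this is the same kind of change as the one from compound 2 to compound 1, but the place is not the same: there the methyl sat two bonds along the chain from an aromatic carbon, here it sits on a saturated chain carbon bound to an aromatic carbon. The expected step from compound 3 to compound 4 is a step that the limit leaves unreadable from compound 3 to compound 4, resting on the limit of > 48000 nM in this assay, at which 2 of the 3 values shown sit, and on the small size of the earlier step. Compound 4 is expected to give 60000 nM, with a range from 30000 nM to 150000 nM, most likely again as a limit.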

Compound 4, half-maximal inhibitory concentration: > 48000 nM
Compound 4 was reported as a limit; the forecaster's own chance of this, stated with the estimate: 85%; the middle value is on the limit's open side.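

No size can be read for the change from compound 3 to compound 4, because both are reported only as limits in this assay: the limit of > 48000 nM in this assay, at which 3 of the 4 values shown sit.

The compounds shown leave open whether hydrogen in place of methyl on a saturated chain carbon bound to an aromatic carbon changes inhibition at all.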